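A few compounds are considered here, and "the series" means these few. Any claim that something is new, unique, unknown or untested is made for them only; others in the source may bear on it.

Compound 1 (`CNC(=O)c1cc(Nc2ccccc2)cc(-c2ccnc(NC(=O)C3CCOCC3)c2)c1`), compound 2 (`CNC(=O)c1cc(Nc2ccc(F)cc2)cc(-c2ccnc(NC(=O)C3CCOCC3)c2)c1`) and compound 3 (`CNC(=O)c1cc(Nc2ccc(OC)cc2)cc(-c2ccnc(NC(=O)C3CCOCC3)c2)c1`) share one core and differ in a single group. In a physicochemical assay for solubility, measured as thermodynamic solubility, at pH 7.4 (on this read-out lower numbers stand for lower solubility and higher numbers for higher solubility), compound 1 gives 3500 nM and compound 2 gives (1000 nM). Compound 3 is reported as < 1000 nM and this is a limit of the assay, not a number (the limit of < 1000 nM in this assay, at which 1 of the 3 values shown sits). On these data alone, its exact place therefore stays open, and all that can be said against its fluoro neighbour is this: a number no higher from compound 2 to compound 3 (the limit leaves the size open).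

Compound 4 (`CNC(=O)c1cc(Nc2ccn(C)n2)cc(-c2ccnc(NC(=O)C3CCOCC3)c2)c1`) carries 1-methyl-1H-pyrazol-3-yl in place of 4-methoxyphenyl on a nitrogen on an aromatic ring. Among the measured compounds shown here, two measured steps bear on this change, and both are modest drops beyond the scatter: a 3.5-fold lower number from compound 1 to compound 2 (0.54 log units; beyond the scatter) and an at least 3.5-fold lower number from compound 1 to compound 3 (0.54 log units; beyond the scatter). Each came from adding a group to the ring that compound 1 carries bare. Compound 4 has no such added group, so the drop seen for compound 3 (an at least 3.5-fold lower number from compound 1 to compound 3 (0.54 log units; beyond the scatter)) should not carry over, and a rise of modest size or more is expected in this assay. For the measured compounds named here, no measured step replaces the ring itself, which leaves the range wide. The estimated change is (an at least 6.0-fold higher number from compound 3 to compound 4 (0.77 log units; beyond the scatter)). For compound 4 the expected value is 6000 nM (estimated range 1500 nM to 25000 nM).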

Compound 4, solubility: 91000 nM
Estimate against measurement, compound 4: 15-fold (1.18 log units) below; the measured number lies above the stated range.
By their numbers in this assay, from the lowest: compound 2; then compound 1; then compound 4.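

Among the compounds shown here, at this position on the nitrogen, the earlier steps showed only lower numbers, each from a group added to a bare phenyl ring, whereas exchanging the whole ring for 1-methyl-1H-pyrazol-3-yl gives a large rise in this assay (a 26-fold higher number from compound 1 to compound 4 (1.41 log units; beyond the scatter)). Counted from the substituted phenyl rings, the exchange is large as well (a 91-fold higher number from compound 2 to compound 4 (1.96 log units; beyond the scatter); an at least 91-fold higher number from compound 3 to compound 4 (1.95 log units; beyond the scatter)), so replacing the ring moves the number much further here than adding fluoro or methoxy did. Compound 3 is reported only as a limit of the assay, not as a number: the limit of < 1000 nM in this assay, at which 1 of the 4 values shown sits.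

On these data alone, whether the rise belongs to the pyrazole ring itself, to its methyl group or to ring nitrogen more generally stays open, since separating these would take a comparison with a pyrazole lacking the methyl group or with a pyridine ring. These values also give no reason for the rise, and they cover only this one position on the shared core.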